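The source may report more compounds than this note shows. Statements on the series, on what has been measured and on what is new or still open speak of the compounds shown alone.

In a functional assay on PC-3 cells (Homo sapiens) for cytotoxicity, read by sulforhodamine B assay, with a stated time of 72 h (a higher number here means a weaker inhibitor, a lower number a stronger inhibitor), the measured compounds are:

compound 1 `Nc1sc(-c2ccc(Cl)cc2)c(-c2ccc(Cl)cc2)c1C(=O)NC1CC1` giving 3680 nM
compound 2 `Nc1sc(-c2ccc(Cl)cc2)c(-c2ccc(Cl)cc2)c1C(=O)NC1CCCCC1` giving 7300 nM
compound 3 `Clc1ccc(-c2sc3ncnc(NC4CC4)c3c2-c2ccc(Cl)cc2)cc1` giving > 50000 nM

Compound 1 and compound 2 share one core and differ in a single place: cyclohexyl in place of cyclopropyl on an amide-type nitrogen. In this assay this change gives a 2.0-fold higher number from compound 1 to compound 2 (0.30 log units; within the scatter). Compound 3 is built on another core; the difference between the core of compound 3 and the core of compound 1 is not broken down here. In this assay compound 3 returns only a limit, > 50000 nM, not a number. This is the limit of > 50000 nM in this assay, at which 1 of the 3 values shown sits.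

Compound 4 `Clc1ccc(-c2sc3ncnc(NC4CCCCC4)c3c2-c2ccc(Cl)cc2)cc1` has not been measured. It differs from compound 3 in one place: cyclohexyl in place of cyclopropyl on a nitrogen on an aromatic ring. This is the same kind of change as that from compound 1 to compound 2, not the same change, since the place differs: in the measured pair the group sits on an amide-type nitrogen whose other neighbours are a carbonyl carbon, whereas in compound 3 and compound 4 it sits on a nitrogen on an aromatic ring whose other neighbours are aromatic carbon.

The expectation for compound 4 rests on two points. The first is a 2.0-fold higher number from compound 1 to compound 2 (0.30 log units; within the scatter), a step within the scatter. The second is that compound 3 itself sits at a limit in this assay. A small step from a limit is expected to leave compound 4 at that limit as well, so the expected step is a step that the limit leaves unreadable from compound 3 to compound 4. Compound 4 is therefore expected to give about 90000 nM in this assay, in a range from 30000 nM to 300000 nM, most likely reported only as a limit.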

Compound 4, half-maximal inhibitory concentration: > 50000 nM
Compound 4: no number, only a limit (the forecaster's own chance of this, stated with the estimate: 80%); the middle value does not contradict the limit.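

In this assay compound 4 gives > 50000 nM, a limit and not a number. No step can be read between compound 3 and compound 4, because both stand at the same limit: the limit of > 50000 nM in this assay, at which 2 of the 4 values shown sit.

The compounds shown leave open what numbers compound 3 and compound 4 would give in this assay, and so whether cyclohexyl in place of cyclopropyl makes any difference on this core.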